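Phenyl for methoxy on two flavone-derived anilide cores

A few compounds are considered here, and "the series" means these few. Any claim that something is new, unique, unknown or untested is made for them only; others in the source may bear on it.

Measured so far:
compound 1, `COc1ccc(NC(=O)COc2ccc3oc(-c4ccccc4)cc(=O)c3c2)cc1`: 840 nM
compound 2, `O=C(COc1ccc2oc(-c3ccccc3)cc(=O)c2c1)Nc1ccc(-c2ccccc2)cc1`: 9710 nM
compound 3, `COc1ccc(NC(=O)COc2ccc3c(=O)cc(-c4ccccc4)oc3c2)cc1`: 5500 nM

In a functional assay on NCI-H661 cells (Homo sapiens) for antiproliferative activity, read by MTT assay, with a stated time of 72 h (on this read-out lower numbers stand for stronger inhibition of growth and higher numbers for weaker inhibition of growth), compound 1 gives 840 nM. Compound 2 differs from it by phenyl in place of methoxy on an aromatic carbon, and this change made a step of a 12-fold higher number from compound 1 to compound 2 (1.06 log units; beyond the scatter). Compound 3 gives 5500 nM in this assay; it has the same atoms as compound 1, joined differently, and the difference between the two cores is not broken down here. Compound 4, `O=C(COc1ccc2c(=O)cc(-c3ccccc3)oc2c1)Nc1ccc(-c2ccccc2)cc1`, carries the same change on the core of compound 3: phenyl in place of methoxy on an aromatic carbon. Among the compounds with values here, with only one earlier case, the expectation for this assay rests on that step alone, and a step of about the same size is expected, a 7.3-fold higher number from compound 3 to compound 4 (0.86 log units; beyond the scatter), because a 12-fold higher number from compound 1 to compound 2 (1.06 log units; beyond the scatter) is the only guide. Compound 4 is therefore expected to give 40000 nM in this assay, between 10000 nM and 150000 nM.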

Compound 4, concentration for 50% growth inhibition: 1280 nM
For compound 4 the middle estimate is 31-fold (1.49 log units) above the measured one; the whole stated range lies above it.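

In this assay, phenyl in place of methoxy on an aromatic carbon gives a 4.3-fold lower number from compound 3 to compound 4 (0.63 log units; beyond the scatter), so the step seen on the core of compound 1 does not carry over to the core of compound 3 and instead reverses in direction: the same change on two cores in this assay, a 12-fold higher number (1.06 log units; beyond the scatter) from compound 1 to compound 2 and a 4.3-fold lower number (0.63 log units; beyond the scatter) from compound 3 to compound 4, 50-fold (1.70 log units) apart, beyond the scatter of two such steps

The outcome of this change therefore depends on the core in these two pairs, and a step measured on one of them is no guide to the other. The two pairs do not show which difference between the cores decides the direction, and they give no rule for any further core.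

As far as these compounds go, it remains open whether an ethoxy group, an amine or a carboxylic acid at the same place would also give steps that differ between the two cores. Also open, from the compounds shown here alone, is how either core would respond to a longer chain between the ring oxygen and the amide.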